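This account rests on a few compounds, and the source may have more. Where it says the series, first, only, none or still open, it means among the compounds named here.

Within the data shown here, in a functional assay on RS4-11 cells (Homo sapiens) for inhibition, read by CCK-8 assay, with a stated time of 48 h (a lower number here means a stronger inhibitor, a higher number a weaker inhibitor), compound 3 `COc1ccc(NC(=O)NCCNS(=O)(=O)c2ccc(-c3ccccc3OCc3cccc(O)c3)s2)cc1` gives 9400 nM, the only exact number so far. Compound 1 `COc1ccc(NC(=O)NCCNS(=O)(=O)c2ccc(-c3ccccc3OCc3ccccc3)s2)cc1` reads > 20000 nM, which is a limit. Compound 2 `COc1ccc(NC(=O)NCCNS(=O)(=O)c2ccc(-c3ccccc3Oc3ccc([N+](=O)[O-])cc3)s2)cc1` reads > 50000 nM, also a limit. Compound 4 `COc1ccc(NC(=O)NCCNS(=O)(=O)c2ccc(-c3ccccc3Oc3ccc([N+](=O)[O-])c([N+](=O)[O-])c3)s2)cc1` differs from compound 3 at one place: 3,4-dinitrophenyl in place of 3-hydroxybenzyl on an oxygen on an aromatic ring. Among the measured compounds shown here, two measured steps bear on this. One is an at least 5.3-fold lower number from compound 2 to compound 3 (0.72 log units; beyond the scatter), with 3-hydroxybenzyl replacing 4-nitrophenyl, and the other is an at least 2.1-fold lower number from compound 1 to compound 3 (0.32 log units; beyond the scatter), with hydroxy replacing hydrogen. Compound 4 loses that hydroxy and, like compound 2, carries a nitro-bearing phenyl, so weaker inhibition is expected, reversing much of an at least 5.3-fold lower number from compound 2 to compound 3 (0.72 log units; beyond the scatter). The expected change is a 3.2-fold higher number from compound 3 to compound 4 (0.50 log units; beyond the scatter). For compound 4, the estimated value is 30000 nM, with an expected range of 10000 nM to 90000 nM.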

Compound 4, half-maximal inhibitory concentration: 1400 nM
Beside the measured number, compound 4's estimate is 21-fold (1.33 log units) above it; the measured number lies below the stated range.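

In this assay, a nitro-bearing phenyl on this oxygen is not a dead end: adding a second nitro gives an at least 35-fold lower number from compound 2 to compound 4 (1.55 log units; beyond the scatter). The 3,4-dinitrophenyl also gives a 6.7-fold lower number from compound 3 to compound 4 (0.83 log units; beyond the scatter) and an at least 14-fold lower number from compound 1 to compound 4 (1.15 log units; beyond the scatter), so among these compounds a hydroxy is not needed for a measurable number. Compound 1 and compound 2 are each held only by a limit, so the two steps starting from them have no exact size.

The compounds shown leave open whether an amine or a carboxylic acid on that phenyl could stand in for the nitro groups.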